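A few compounds are considered here, and "the series" means these few. Any claim that something is new, unique, unknown or untested is made for them only; others in the source may bear on it.

Of the compounds shown here, two have so far been measured in an ADME assay on a cell-free system (plasma, Rattus norvegicus, strain Sprague-Dawley) for metabolic stability, read by LC-MS, with a stated time of 3 h, tested at 1 uM; a lower number here means that less of the compound is left, a higher number that more of the compound is left. Compound 1 `Cc1ccnc(NC(c2ccc([N+](=O)[O-])cc2)c2ccc3cccnc3c2O)c1` gives 100% in this assay, and compound 2 `COc1ccc(C(Nc2ccccn2)c2ccc3cccnc3c2O)cc1` gives 42.2%. Compound 2 therefore stands lowest of the two numbers; its nearest neighbour is compound 1, which sits higher by an amount beyond the usual scatter. The two compounds differ in more than one place, so no single structural step between measured compounds is available, and nothing in the data explains that gap.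

Compound 3 `Oc1c(CNc2ccccn2)ccc2cccnc12` is the next compound to be measured in this assay. It differs from compound 2 in a single place: hydrogen in place of 4-methoxyphenyl on a saturated chain carbon bound to an aromatic carbon and a nitrogen on an aromatic ring. Whether this change helps or hurts cannot be read from the two measured compounds, since neither of them shares it. The expectation is therefore a cautious one, leaning upward from compound 2 toward the middle of the range seen so far. The step of a number 17.8 percentage points higher from compound 2 to compound 3 (beyond the scatter) is expected to be a modest rise, though it may well fall within the scatter. Compound 3 is estimated to give 60% in this assay, with a range from 25% to 95%.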

Compound 3, percent of the compound remaining in the plasma assay: 76.3%
Estimate against measurement, compound 3: 16.3 percentage points below; low and high end bracket the measured number.
By their numbers in the plasma assay, from the lowest: compound 2; then compound 3; then compound 1.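

Among the compounds shown here, this is the first step that changes only one place. In the plasma assay, hydrogen in place of 4-methoxyphenyl on a saturated chain carbon gives a number 34.1 percentage points higher from compound 2 to compound 3 (beyond the scatter), so the group on this carbon clearly matters for how much compound is left, and the 4-methoxyphenyl is not needed for a high number. In a physicochemical assay for solubility, using the shake flask method, with a stated time of 24 h, at pH 6.8 (a higher number here means a more soluble compound, a lower number a less soluble compound), compound 2 gives 5.3 nM and compound 3 gives 111 nM. In the physicochemical assay the same change reads a 21-fold higher number from compound 2 to compound 3 (1.32 log units; beyond the scatter), so both numbers rise together, although a single pair of compounds cannot show that one rise follows from the other.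

Going by these compounds, it remains open whether the higher numbers come from losing the whole ring or only the methoxy group on it, as this pair compares nothing between 4-methoxyphenyl and hydrogen. A plain phenyl or a small methyl group on the same carbon would begin to separate these two readings, and would show whether each number changes gradually or only once the ring is gone.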